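From acetoxymethyl to methoxymethyl: notes on compound 3

A few compounds are considered here, and "the series" means these few. Any claim that something is new, unique, unknown or untested is made for them only; others in the source may bear on it.

In a functional assay on MDA-MB-231 cells (Homo sapiens) for cytotoxicity, read by sulforhodamine B assay, with a stated time of 3 days (on this read-out lower numbers stand for an effect already at smaller amounts and higher numbers for an effect only at larger amounts of compound), compound 1 `COC(=O)c1c(C)coc1-c1ccc2c(c1OC)CCCC2(C)C` gives 61 uM and compound 2 `COc1c(-c2occ(C)c2COC(C)=O)ccc2c1CCCC2(C)C` gives 55.6 uM. Going by the values given here, compound 2 therefore lies within the scatter of its only measured neighbour, and the two cannot be ranked. Both numbers sit at the same level, with nothing else in the series to compare them against.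

Compound 3 `COCc1c(C)coc1-c1ccc2c(c1OC)CCCC2(C)C` keeps the shared core of compound 2 and has methyl in place of acetyl on an oxygen on a saturated carbon. The same difference reads as acetoxymethyl to methoxymethyl.

Among the compounds with values here, only one measured step bears on this change: a 1.1-fold lower number from compound 1 to compound 2 (0.04 log units; within the scatter), with acetoxymethyl in place of methoxycarbonyl on an aromatic carbon. Within the data shown here, that step alters the same substituent of compound 2 and stays within the scatter, but it is indirect evidence, as no measured pair exchanges acetyl for methyl. No shift beyond the scatter is therefore expected in this assay. The expected step is a 1.1-fold lower number from compound 2 to compound 3 (0.05 log units; within the scatter). The estimate for compound 3 is 50 uM, with an expected range from 25 uM to 100 uM.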

Compound 3, concentration for half-maximal effect: 47.8 uM
For compound 3 the middle estimate is 1.0-fold (0.02 log units) above the measured one; measured number inside the range.
By their numbers in this assay, from the lowest: compounds 3, 2 and 1 (each within the scatter of the next).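

In this assay the direct exchange on the oxygen gives a 1.2-fold lower number from compound 2 to compound 3 (0.07 log units; within the scatter), so replacing acetyl with methyl on an oxygen on a saturated carbon, which removes the double bond and hydrogen-bond acceptor counted for acetyl, does not move the number beyond the scatter. The step of a 1.3-fold lower number from compound 1 to compound 3 (0.11 log units; within the scatter) adds a second reading, so methoxycarbonyl, acetoxymethyl and methoxymethyl now cannot be told apart at this place in this read-out. No measurement shown gives a reason why these three compounds stay so close together.

As far as these compounds go, whether the numbers stay together with a different kind of group on this oxygen-bearing side chain, such as an amine, a carboxylic acid or a longer alkyl chain on the oxygen, remains open. From the compounds shown here alone, with only these three compounds, all of which share the same core and differ at this one place, it also remains open whether any change here or elsewhere on the core can shift the number beyond the scatter.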